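Oxan-4-yl to Cyclohexyl on a Benzoxazolone Carbamate Core

This account rests on a few compounds, and the source may have more. Where it says the series, first, only, none or still open, it means among the compounds named here.

Measured compounds:
compound 1, `O=C(NCCCCc1ccccc1)n1c(=O)oc2cc(C3CCOCC3)ccc21`, 68 nM
compound 2, `CCC(C)NC(=O)n1c(=O)oc2cc(C3CCN(C)CC3)ccc21`, 2100 nM

The study measured two compounds in an assay on HEK293 cells for inhibition of acid ceramidase (Homo sapiens), read by fluorescence, with stated times of 10 min and 3 h; a lower number here means a stronger inhibitor, a higher number a weaker inhibitor. Compound 1 gives 68 nM, and compound 2 gives 2100 nM. Compound 1 therefore stands at the lowest of the two numbers, and the gap between compound 1 and compound 2 lies beyond the scatter of repeated measurements. Within the data shown here, compound 2 differs from compound 1 in more than one place, so no single step between measured compounds is available to guide the next change.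

The third compound is compound 3, `O=C(NCCCCc1ccccc1)n1c(=O)oc2cc(C3CCCCC3)ccc21`, which has not yet been measured in this assay. It differs from compound 1 in one place: cyclohexyl in place of oxan-4-yl on an aromatic carbon. The rest of the shared core and the chain on the carbamate nitrogen are unchanged.

Among the measured compounds shown here, with no measured step of this kind to lean on, the expected step in this assay from compound 1 to compound 3 is small, at most a modest change in either direction, and likely none beyond the scatter, giving an estimated 1.2-fold lower number from compound 1 to compound 3 (0.09 log units; within the scatter). Compound 3 is therefore expected to give about 55 nM, with a range from 15 nM to 200 nM.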

Compound 3, half-maximal inhibitory concentration: 89 nM
The estimate for compound 3 lay 1.6-fold (0.21 log units) below the measured number; low and high end bracket the measured number.
By their numbers in this assay, from the lowest: compounds 1 and 3 (each within the scatter of the next); then compound 2.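

In this assay, among these compounds, the exchange of oxan-4-yl for cyclohexyl on the aromatic carbon gives a 1.3-fold higher number from compound 1 to compound 3 (0.12 log units; within the scatter), the first step that can be read at a single position. With the rest of the shared core and the chain on the carbamate nitrogen held constant, the ring oxygen of oxan-4-yl, the one hydrogen-bond acceptor in that group, can give way to carbon without a shift in the number beyond the scatter, so this pair shows no dependence on that acceptor at this position. No measurement shown here offers an explanation for this result.

The compounds shown leave open whether the same holds with any other chain on the carbamate nitrogen, since compound 1 and compound 3 share theirs and compound 2 differs from both in more than one place. They also leave open how this position responds to a group other than a six-membered non-aromatic ring, such as a cyclopropyl ring or a phenyl ring, or to a cyclohexyl ring carrying a hydroxyl group or a carboxylic acid.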